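Oxime ether series: thienyl in place of pyridinyl

A few compounds are considered here, and "the series" means these few. Any claim that something is new, unique, unknown or untested is made for them only; others in the source may bear on it.

compound 1 `Clc1ccc(COc2ccc(/C=C/C(/C=C/c3ccccn3)=N/Oc3ncnc4ccccc34)cc2)cc1`: 94.4%
compound 2 `Clc1ccc(COc2ccc(/C=C/C(/C=C/c3ccccn3)=N/Oc3ncnc4ccccc34)cc2)c(Cl)c1`: 89.6%

In a functional assay on SMMC-7721 cells (Homo sapiens) for inhibition, read by MTT assay, with a stated time of 72 h, tested at 10 uM (a higher number here means a stronger effect of the compound at the concentration tested, a lower number a weaker effect), compound 1 gives 94.4%, the highest of the two numbers shown. Compound 2 gives 89.6%; the step of a number 4.8 percentage points lower from compound 1 to compound 2 (within the scatter) lies within the scatter. Compound 3 `Clc1ccc(COc2ccc(/C=C/C(/C=C/c3cccs3)=N/Oc3ncnc4ccccc34)cc2)cc1` is not yet measured; it differs from compound 1 thus: thiophen-2-yl in place of pyridin-2-yl on a double-bonded chain carbon bound to a double-bonded chain carbon. The one measured step concerns a chloro on a different ring and does not bear on this exchange; nothing shown separates the two heteroaryl groups. No step beyond the scatter is therefore expected, a number 6.4 percentage points lower from compound 1 to compound 3 (within the scatter). For compound 3 the expected value in this assay is 88%, range 70% to 98%.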

Compound 3, a percentage reported as inhibition, at one concentration (the size of the read-out at that concentration, not a potency): 97.5%
The estimate for compound 3 lay 9.5 percentage points below the measured number, and the stated range covers the measured number.
By their numbers in this assay, from the lowest: compounds 2, 1 and 3 (each within the scatter of the next).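

The pyridin-2-yl group on this double-bonded chain carbon can be exchanged for thiophen-2-yl without a step beyond the scatter: in this assay the exchange gives a number 3.1 percentage points higher from compound 1 to compound 3 (within the scatter). The ring nitrogen of pyridin-2-yl is therefore not needed to keep this read-out at the tested concentration, and a five-membered aromatic ring with sulfur serves in its place. Nothing measured on these compounds accounts for the result.

Furan-2-yl, phenyl or a ring carrying a dimethylamino group at this place remains open. So does the second chloro of compound 2 alongside thiophen-2-yl, and whether the effect of these compounds would be stronger or weaker at any other concentration: a single concentration was tested.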